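Trifluoromethyl step from compound 3 to compound 4

This account rests on a few compounds, and the source may have more. Where it says the series, first, only, none or still open, it means among the compounds named here.

Measured in an ADME assay on BHK-21 cells (Mesocricetus auratus) for cytotoxicity, read by MTT assay; on this read-out lower numbers stand for higher toxicity in this test and higher numbers for lower toxicity in this test:
- compound 1 `CC(=O)c1ccc2[nH]c(-c3ccc(C(F)(F)F)cc3)nc2c1`: > 100000 nM, a limit
- compound 2 `C/C(=N\O)c1ccc2[nH]c(-c3ccc(C(F)(F)F)cc3)nc2c1`: "not determined" (no result reported)
- compound 3 `C/C(=N\NC(N)=O)c1ccc2[nH]c(-c3ccccc3)nc2c1`: > 100000 nM, a limit

In this assay compound 3 gives only a limit, > 100000 nM, and no number. Within the data shown here, the series so far shows (the limit of > 100000 nM in this assay, at which 2 of the 3 values shown sit). Compound 4 `C/C(=N\NC(N)=O)c1ccc2[nH]c(-c3ccc(C(F)(F)F)cc3)nc2c1` carries trifluoromethyl in place of hydrogen on an aromatic carbon, para to a large group (trifluoromethyl in place of hydrogen on an aromatic carbon). Among the measured compounds shown here, no step between measured compounds is available. Compound 1 also carries trifluoromethyl, and its reading of > 100000 nM is again a limit. No change beyond the usual scatter is therefore expected, and another limit is the likely report. The expected step is a number no higher from compound 3 to compound 4 (the limit leaves the size open). For compound 4 the estimated value is 100000 nM, with an expected range of 30000 nM to 200000 nM.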

Compound 4, half-maximal cytotoxic concentration: > 100000 nM
Compound 4: a limit, no number; the forecaster's own chance of this, stated with the estimate: 70%; the middle value sits exactly at the limit.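

Compound 1, compound 3 and compound 4 all give limits in this assay, so neither step to compound 4 can be read: the limit of > 100000 nM in this assay, at which 3 of the 4 values shown sit.

The compounds shown leave open whether trifluoromethyl in place of hydrogen on an aromatic carbon shifts this read-out at all.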